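The compounds below may be only part of what the source reports. "The series", "measured", "known", "first", "only" and "open" are said of these compounds alone.

Measured so far:

Compound 1, `O=C1c2cc(Cl)c(Cl)cc2C(=O)N1c1ncccn1`: 58%
Compound 2, `O=C1c2cc(Cl)c(Cl)cc2C(=O)N1c1ccncc1`: 19%
Compound 3, `O=C1c2c(Cl)c(Cl)c(Cl)c(Cl)c2C(=O)N1c1ccncc1`: 44%

All three compounds were tested in a functional assay on the whole organism (serum, strain Swiss albino) with Rattus norvegicus as the target, read by spectrophotometry, with a stated time of 14 days, at a dose of 10 mg/kg by the oral route; a higher number here means more inhibition at the dose given (going by the name of the read-out), a lower number less inhibition. Compound 2 gives 19%, the lowest of the three numbers. It differs in one place only from compound 1, and compound 1 gives 58%. The change between them is pyrimidin-2-yl in place of pyridin-4-yl on an amide-type nitrogen in a ring, and it made a step of a number 39 percentage points higher from compound 2 to compound 1 (beyond the scatter).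

Compound 3 gives 44%. It shares with compound 2 the same group on the amide-type nitrogen in the ring, but its core carries more chlorine atoms; the difference between the two cores is not broken down here, so the two values can only be set side by side.

The unmeasured compound 4, `O=C1c2c(Cl)c(Cl)c(Cl)c(Cl)c2C(=O)N1c1ncccn1`, stands to compound 3 as compound 1 stands to compound 2: the change is pyrimidin-2-yl in place of pyridin-4-yl on an amide-type nitrogen in a ring, at the same place in the same words, so it is the same change made on a different core. Among the compounds with values here, the one earlier example of this change gave a large step upward. Because that step was a number 39 percentage points higher from compound 2 to compound 1 (beyond the scatter), compound 4 is expected to sit well above compound 3, with a step of about a number 28 percentage points higher from compound 3 to compound 4 (beyond the scatter) in this assay. The expectation rests on a single earlier pair, so the range is kept wide. Compound 4 is estimated at 72%, with a likely spread from 52% to 90%.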

Compound 4, a percentage reported as inhibition, in the whole organism at one dose (the size of the read-out at that dose, not a potency): 3%
Compound 4: middle estimate off by 69 percentage points, on the high side, and the stated range ends above it.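

On the core of compound 3, putting pyrimidin-2-yl in place of pyridin-4-yl on an amide-type nitrogen in a ring gave a number 41 percentage points lower from compound 3 to compound 4 (beyond the scatter) in this assay, so the upward step seen on the other core did not carry over. Within the data shown here, the same change moved the result in opposite directions on the two cores, which shows that in these four compounds its effect depends on the core it is made on, and a step measured on one core is no guide to the step on the other: the same change on two cores in this assay, a number 39 percentage points higher (beyond the scatter) from compound 2 to compound 1 and a number 41 percentage points lower (beyond the scatter) from compound 3 to compound 4, 80 percentage points apart, beyond the scatter of two such steps. This does not show why the direction reverses, since the data do not separate possible causes, and two pairs at a single dose cannot tell which direction a further core would follow.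

Left open is how the series would respond to a different group on that nitrogen, such as a plain phenyl ring, an amine or a carboxylic acid, since only pyridin-4-yl and pyrimidin-2-yl appear there. Also open is whether a core with a number of chlorine atoms other than those shown would follow compound 1 or compound 4 when the same change is made.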